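Compound 3 to compound 4: same atoms, joined differently

The source may report more compounds than this note shows. Statements on the series, on what has been measured and on what is new or still open speak of the compounds shown alone.

Among the measured compounds shown here, three amides have numbers so far in an ADME assay on microsomes from liver (Mus musculus) for metabolic stability, read by LC-MS, with a stated time of 30 min, tested at 1 uM (a lower number here means that less of the compound is left, a higher number that more of the compound is left), and they spread widely. In this assay compound 1 `O=C(NCc1ccc(S(=O)(=O)c2ccccc2)cc1)c1cc(-c2cccnc2)[nH]n1` gives 42% as the highest of the three, and compound 2 `O=C(NCc1ccc(S(=O)(=O)N2CCCCC2)cc1)c1cnc2nccn2c1` gives 0.28% as the lowest. Compound 3 `O=C(NCc1ccc(S(=O)(=O)c2ccccc2)cc1)c1cn2ccnc2cn1` gives 13% and stands second, with both gaps beyond the usual scatter.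

Compound 4 `O=C(NCc1ccc(S(=O)(=O)c2ccccc2)cc1)c1cnc2nccn2c1` has the same atoms as compound 3 but joined differently, and the change sits on a carbonyl carbon: a group of 9 heavy atoms (6 carbon, 3 nitrogen; one five-membered aromatic ring with 2 hetero atoms, one six-membered aromatic ring with 2 hetero atoms) in place of a group of 9 heavy atoms (6 carbon, 3 nitrogen; one five-membered aromatic ring with 2 hetero atoms, one six-membered aromatic ring with 2 hetero atoms), on a carbonyl carbon is the only difference. For the measured compounds named here, no measured pair isolates this change, so the size of the step cannot be read directly from the data. The nearest evidence is compound 2, which carries the entering group on a different remainder of the molecule and gives 0.28% in this assay. That value points towards less compound remaining, but the different remainder limits how much weight it can bear. The expected change is a number 7 percentage points lower from compound 3 to compound 4 (within the scatter) and this modest fall may not clear the scatter. For compound 4 the estimated value is 6% with an expected range of 1% to 20% in this read-out.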

Compound 4, percent of the compound remaining: 30%
Estimate against measurement, compound 4: 24 percentage points below; the measured number lies above the stated range.
By their numbers in this assay, from the lowest: compound 2; then compound 3; then compound 4; then compound 1.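

Compound 3 and compound 4 have the same atoms, joined differently, yet in this assay the group on the carbonyl carbon gives a number 17 percentage points higher from compound 3 to compound 4 (beyond the scatter), so the count of atoms and rings in this group does not fix the amount of compound remaining. Among the compounds shown here, with that carbonyl group held constant, phenyl in place of piperidin-1-yl on a sulfonyl sulfur gives a number 29.7 percentage points higher from compound 2 to compound 4 (beyond the scatter), which shows for the first time that the group on the sulfonyl sulfur also moves this read-out on its own. No measurement in hand gives a reason for either step.

As far as these compounds go, the two steps rest on single pairs, so it remains open whether the sulfonyl step would carry over to the carbonyl group of compound 3, or whether the carbonyl step would carry over to a piperidin-1-yl sulfonamide. Also open, from the compounds shown here alone, is where a morpholin-4-yl or a dimethylamino group on the sulfonyl sulfur would fall relative to phenyl and piperidin-1-yl with the carbonyl group of compound 4 kept in place.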